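Methoxy for ethyl on two amide cores

The compounds below may be only part of what the source reports. "The series", "measured", "known", "first", "only" and "open" are said of these compounds alone.

Compound 1 `COc1ccc(-c2ccc(C(=O)Nc3ccc(Oc4ccnc5[nH]ccc45)cc3)nc2)cc1` and compound 2 `CCc1ccc(-c2ccc(C(=O)Nc3ccc(Oc4ccnc5[nH]ccc45)cc3)nc2)cc1` share one core. In a functional assay on A549 cells (Homo sapiens) for cytotoxicity, read by MTT assay, with a stated time of 72 h (on this read-out higher numbers stand for weaker inhibition and lower numbers for stronger inhibition), compound 1 reaches only the assay limit, > 10000 nM. In this assay compound 2 likewise gives a limit, > 10000 nM. The change methoxy in place of ethyl on an aromatic carbon therefore gives a step that the two limits leave unreadable from compound 2 to compound 1, unreadable because both values sit at the limit of > 10000 nM in this assay, at which 2 of the 3 values shown sit. Compound 3 `CCc1ccc(-c2ccnc(C(=O)Nc3ccc(Oc4ccnc5[nH]ccc45)c(F)c3)c2)cc1` carries a second core; the difference between the two cores is not broken down here. In this assay, among the compounds with values here, compound 3 gives 3370 nM, the only number. Compound 4 `COc1ccc(-c2ccnc(C(=O)Nc3ccc(Oc4ccnc5[nH]ccc45)c(F)c3)c2)cc1` arises by methoxy in place of ethyl on an aromatic carbon, the same change as before, at a place described in the same words. With no readable precedent, the step from compound 3 to compound 4 is expected near nil, a 1.5-fold higher number from compound 3 to compound 4 (0.17 log units; within the scatter), resting on the unreadable a step that the two limits leave unreadable from compound 2 to compound 1. Compound 4 is estimated at 5000 nM, within 1500 nM to 15000 nM.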

Compound 4, half-maximal inhibitory concentration: 1040 nM
For compound 4 the middle estimate is 4.8-fold (0.68 log units) above the measured one, and the stated range ends above it.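

In this assay, methoxy in place of ethyl gives a 3.2-fold lower number from compound 3 to compound 4 (0.51 log units; beyond the scatter), a modest but readable effect of the 4-ethylphenyl to 4-methoxyphenyl change on the core of compound 3. It does not show that the step carries from one core to the other, as the step from compound 2 to compound 1 cannot be read: the limit of > 10000 nM in this assay, at which 2 of the 4 values shown sit. One readable step on one core therefore sets no rule for the series.

From the compounds shown here alone, what an amine or a longer chain such as propyl would give in the same place remains open on both cores. Also open, going by these compounds, is which of the differences between the two cores separates compound 2 from compound 3.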